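This account rests on a few compounds, and the source may have more. Where it says the series, first, only, none or still open, it means among the compounds named here.

Going by the values given here, in a physicochemical assay for solubility, read by HPLC, using the shake flask method, in phosphate buffer, measured as kinetic solubility, with a stated time of 20 h, at pH 6.5 (on this read-out higher numbers stand for higher solubility and lower numbers for lower solubility), compound 1 `Fc1ccc(Nc2cc3[nH]c(Nc4ccc(N5CCNCC5)cn4)nc3cn2)cc1C(F)(F)F` gives 180000 nM as the only actual number so far. Compound 2 `C[C@@H]1CN(c2ccc(Nc3nc4cnc(Nc5ccc(F)c(C(F)(F)F)c5)cc4[nH]3)nc2)C[C@H](C)O1` reports < 5000 nM and that is a limit. Among the compounds with values here, the one measured step of an at least 36-fold lower number from compound 1 to compound 2 (1.55 log units; beyond the scatter) is large, but it puts 2,6-dimethylmorpholin-4-yl in place of piperazin-1-yl and gives no size for the change at hand. Compound 3 `Fc1ccc(Nc2cc3[nH]c(Nc4ccc(N5CCNCC5)cn4)nc3cn2)cc1F` carries fluoro in place of trifluoromethyl on an aromatic carbon and keeps piperazin-1-yl. Within the data shown here, no measured step covers this change, so the expected step of a 1.1-fold higher number from compound 1 to compound 3 (0.02 log units; within the scatter) in this assay stays within the scatter, with no direction expected. Compound 3 is estimated at 190000 nM with an expected range of 90000 nM to 380000 nM here.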

Compound 3, solubility: < 5000 nM
Compound 3: no number, only a limit (the forecaster's own chance of this, stated with the estimate: 20%); middle value at least 38-fold (1.57 log units) away from the limit.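

In this assay the 4-fluoro-3-(trifluoromethyl)phenyl side of the series also matters: with piperazin-1-yl kept, fluoro in place of trifluoromethyl on an aromatic carbon gives an at least 36-fold lower number from compound 1 to compound 3 (1.55 log units; beyond the scatter). Going by these compounds alone, the earlier step touched only the piperazin-1-yl side, so this is the first reading at this position. Compound 3 reports a limit and not a number, so the step gives only a bound: the limit of < 5000 nM in this assay, at which 2 of the 3 values shown sit.

On these data alone, how a chlorine, a nitrile or a methoxy group would read at this position remains open. So does how far compound 2 and compound 3 lie beyond their limits.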